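Cyano on the benzyl ether of compound 3

The source may report more compounds than this note shows. Statements on the series, on what has been measured and on what is new or still open speak of the compounds shown alone.

Measured compounds:
Compound 1 `Cc1cc(=O)oc2cc(SCc3cccc(OC(F)(F)F)c3)ccc12` gives 14800 nM in a functional assay on KB cells (Homo sapiens) for antiproliferative activity, read by sulforhodamine B assay, with a stated time of 72 h; on this read-out lower numbers stand for stronger inhibition of growth and higher numbers for weaker inhibition of growth.
Compound 2 `CCc1cc(=O)c2ccc(Sc3cccc(Cl)[n+]3[O-])cc2o1` gives only a limit, > 29900 nM, in this assay.
Compound 3 `CCc1cc(=O)c2ccc(OCc3ccccc3)c(C)c2o1` gives only a limit, > 33900 nM, in this assay.

Compound 3 stands among the weak end of the values shown: its result is a limit of the assay rather than a number, and it sits at the limit of > 33900 nM in this assay, at which 1 of the 3 values shown sits. Compound 2 likewise sits at a limit, (the limit of > 29900 nM in this assay, at which 1 of the 3 values shown sits). Only compound 1 gives a number in this assay.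

Compound 4 `CCc1cc(=O)c2ccc(OCc3cccc(C#N)c3)c(C)c2o1` is the next compound. It differs from compound 3 in one place: cyano in place of hydrogen on an aromatic carbon, meta to a large group.

No step between measured compounds is shown that bears on this change, so the account rests on compound 3 alone. Since compound 3 reaches only a limit, there is no firm number from which a step can be counted. The expected step from compound 3 to compound 4 is a step that the limit leaves unreadable from compound 3 to compound 4, no larger than the scatter in either direction. Compound 4 is therefore expected to give 40000 nM, within the range 10000 nM to 160000 nM, and most likely again only a limit.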

Compound 4, concentration for 50% growth inhibition: > 31300 nM
Compound 4: no number, only a limit; the forecaster's own chance of this, stated with the estimate: 70%; the middle value lies beyond the limit too.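

In this assay compound 3 and compound 4 both give only a limit of the assay and not a number, so no step can be read between them. The compounds shown leave open whether cyano in place of hydrogen on an aromatic carbon changes growth inhibition at all, and in which direction.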